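Trimming the Side Chain of Compound 2 to Hydrogen

This account rests on a few compounds, and the source may have more. Where it says the series, first, only, none or still open, it means among the compounds named here.

Among the compounds with values here, compound 2 `CSCC[C@H](NC(=O)CN(c1ncnc2c1ncn2C1CCCCO1)C1CC1)C(=O)OCc1ccccc1` holds the higher of the two numbers measured so far: in a functional assay on the whole organism (Tail, strain ICR) with Mus musculus as the target, in the tail flick test, with a stated time of 90 min, at a dose of 25 umol/kg by the oral route (on this read-out lower numbers stand for a weaker effect and higher numbers for a stronger effect at the one dose given), compound 2 gives 42.7%, whereas compound 1 `CC[C@H](C)[C@H](NC(=O)CN(c1ncnc2c1ncn2C1CCCCO1)C1CC1)C(=O)OCc1ccccc1` gives 22.6%. Within the data shown here, the single measured step, a number 20.1 percentage points higher from compound 1 to compound 2 (beyond the scatter), lies beyond the scatter. Compound 3 `C[C@H](NC(=O)CN(c1ncnc2c1ncn2C1CCCCO1)C1CC1)C(=O)OCc1ccccc1` has not yet been measured; it differs from compound 2 by hydrogen in place of (methylsulfanyl)methyl on a saturated chain carbon, two bonds along the chain from an amide-type nitrogen and a carbonyl carbon. Among the measured compounds shown here, no measured step removes a side chain altogether, so the step from compound 1 to compound 2 bears on this change only loosely, showing that exchanging one side chain for another moved the read-out by a modest amount. Taking that as a sign that the side chain matters, compound 3 is expected to give 27%, between 10% and 48%. The estimated step is a number 15.7 percentage points lower from compound 2 to compound 3 (beyond the scatter), a drop expected because compound 2 reached 42.7% while compound 1 gave 22.6%.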

Compound 3, a percentage reported as activity, at one dose (the size of the read-out at that dose, not a potency): 32.1%
Estimate against measurement, compound 3: 5.1 percentage points below; the range from low to high includes it.
By their numbers in this assay, from the lowest: compounds 1 and 3 (each within the scatter of the next); then compound 2.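

In this assay, the step to hydrogen in place of (methylsulfanyl)methyl is a number 10.6 percentage points lower from compound 2 to compound 3 (beyond the scatter), so the methyl side chain left behind does not keep the read-out that the 2-(methylsulfanyl)ethyl side chain gives. The other new step, a number 9.5 percentage points higher from compound 1 to compound 3 (within the scatter), means that methyl and sec-butyl cannot be told apart at this position, and only 2-(methylsulfanyl)ethyl stands apart, with its steps to both others beyond the scatter. No supporting data bear on why the read-out moves with this side chain.

The compounds shown leave open whether the sulfur atom or the straight chain carries the difference, which a plain butyl chain at the same carbon would help to separate. They also leave open how a side chain ending in an amine or a carboxylic acid would read.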